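Solubility notes: from compound 2 to compound 3

The source may hold more compounds than are shown below. What is called first, only, known or untested is meant among the compounds shown, and "the series" means these compounds.

In a physicochemical assay for solubility, read by HPLC, using the shake flask method, measured as kinetic solubility, with a stated time of 20 h, at pH 6.5, tested at 200 uM (on this read-out higher numbers stand for higher solubility and lower numbers for lower solubility), compound 1 `CS(=O)(=O)c1cccc(-c2ccc3nccc(N4CCNCC4)c3n2)c1` gives 165000 nM as a measured number. Compound 2 `NS(=O)(=O)c1cccc(-c2ccc3nccc(-c4cccnc4)c3n2)c1` stands at < 5000 nM on the same read-out, and this is only a limit of the assay, not a number.

Compound 3 `NS(=O)(=O)c1cccc(-c2ccc3nccc(-c4ccncc4F)c3n2)c1` carries 3-fluoropyridin-4-yl in place of pyridin-3-yl on an aromatic carbon of the shared core, opposite the ring nitrogen. Among the compounds with values here, the counted difference is 3-fluoropyridin-4-yl in place of pyridin-3-yl on an aromatic carbon and no measured pair tests this change.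

The expected step is a step that the limit leaves unreadable from compound 2 to compound 3 and it is not expected to go beyond the usual scatter in either direction. This expectation rests on compound 2 at < 5000 nM as a limit alone. Compound 3 is estimated at 4000 nM with an expected range from 1500 nM to 15000 nM in this assay for now.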

Compound 3, solubility: < 5000 nM
Compound 3: a limit, no number (the forecaster's own chance of this, stated with the estimate: 60%); the middle value does not contradict the limit.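

No step can be read from compound 2 to compound 3 in this assay, because both stand at a limit of the assay and not at a number: the limit of < 5000 nM in this assay, at which 2 of the 3 values shown sit.

The compounds shown leave open whether 3-fluoropyridin-4-yl in place of pyridin-3-yl on an aromatic carbon moves the read-out of this assay in either direction.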